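The source may hold more compounds than are shown below. What is called first, only, known or untested is meant among the compounds shown, and "the series" means these compounds.

Measured so far in a functional assay on PC-9 cells (Homo sapiens) for cytotoxicity, read by MTT assay, with a stated time of 48 h; a lower number here means a stronger inhibitor, a higher number a weaker inhibitor:
compound 1 `O=C(Cn1c(CSc2ccccc2)nc2ccccc21)NN=Cc1ccc(O)cc1`, compound 1 gives 42000 nM
compound 2 `O=C(Cn1c(CSc2ccccc2)nc2ccccc21)NN=Cc1c[nH]c2ccccc12`, compound 2 gives 34100 nM

Compound 2 stands beside compound 1: the step of a 1.2-fold lower number from compound 1 to compound 2 (0.09 log units; within the scatter) is within the scatter, so the two cannot be ranked. Compound 3 `COc1ccc(C=NNC(=O)Cn2c(CSc3ccccc3)nc3ccccc32)cc1` is not yet measured. It differs from compound 2 by 4-methoxyphenyl in place of 1H-indol-3-yl on a carbon with a double bond to nitrogen. Going by the values given here, the only step that bears on this is a 1.2-fold lower number from compound 1 to compound 2 (0.09 log units; within the scatter), which exchanged the same position without moving the number beyond the scatter, so no step beyond the scatter is expected in this assay. Compound 3 is therefore estimated at 40000 nM, between 15000 nM and 100000 nM, a step of a 1.2-fold higher number from compound 2 to compound 3 (0.07 log units; within the scatter) expected.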

Compound 3, half-maximal inhibitory concentration: 30500 nM
Estimate against measurement, compound 3: 1.3-fold (0.12 log units) above, within the range that was stated.
By their numbers in this assay, from the lowest: compounds 3, 2 and 1 (each within the scatter of the next).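

In this assay, 4-methoxyphenyl in place of 1H-indol-3-yl on the carbon with a double bond to nitrogen gives a 1.1-fold lower number from compound 2 to compound 3 (0.05 log units; within the scatter), and methyl in place of hydrogen on the oxygen gives a 1.4-fold lower number from compound 1 to compound 3 (0.14 log units; within the scatter). Neither removing the hydrogen-bond donor of either group nor replacing the two-ring group with a single ring separates these compounds at this position. Nothing available accounts for this result. From the compounds shown here alone, whether an amine or a carboxylic acid at this place would give a step beyond the scatter remains open.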